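Exchanging a five-membered ring for a six-membered one

The compounds below may be only part of what the source reports. "The series", "measured", "known", "first", "only" and "open" are said of these compounds alone.

Among the three compounds measured in an assay on isolated protein for inhibition of DNA topoisomerase 1 (Homo sapiens), with a stated time of 30 min, tested at 100 uM (a lower number here means a weaker effect, a higher number a stronger effect of the compound at the concentration tested), compound 3 `Oc1ccc(-c2cc(-c3cccc(Cl)c3)nc(-c3cccs3)c2)cc1` stands highest with 52.4%. Compound 2 `Oc1ccc(-c2cc(-c3cccs3)nc(-c3ccccc3Cl)c2)cc1` gives 2.2%, and compound 1 `Oc1cccc(-c2cc(-c3ccncc3)nc(-c3cccc(Cl)c3)c2)c1` gives 0%. For the measured compounds named here, the only step recorded between measured compounds is a number 50.2 percentage points higher from compound 2 to compound 3 (beyond the scatter), and it concerns the chlorophenyl group, not the ring that changes here. Compound 4 `Oc1ccc(-c2cc(-c3ccncc3)nc(-c3cccc(Cl)c3)c2)cc1` differs from compound 3 by pyridin-4-yl in place of thiophen-2-yl on an aromatic carbon. Going by the values given here, no measured step bears directly on this exchange; compound 1, which also carries a pyridin-4-yl group and a 3-chlorophenyl group, gives 0% in this assay. Compound 4 is therefore expected to fall below compound 3, a step of a number 32.4 percentage points lower from compound 3 to compound 4 (beyond the scatter). The estimate for compound 4 is 20%, expected to lie between 0% and 50%.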

Compound 4, a percentage reported as inhibition, at one concentration (the size of the read-out at that concentration, not a potency): 29.2%
Compound 4: the middle estimate sits 9.2 percentage points below what was measured; the measured number falls inside the stated range.
By their numbers in this assay, from the lowest: compounds 1 and 2 (each within the scatter of the next); then compound 4; then compound 3.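

Next to the ring nitrogen, the change from thiophen-2-yl to pyridin-4-yl costs part of the effect but does not abolish it, with a number 23.2 percentage points lower from compound 3 to compound 4 (beyond the scatter) in this assay. The placement of the hydroxyl group also matters with pyridin-4-yl in place, shown by a number 29.2 percentage points higher from compound 1 to compound 4 (beyond the scatter), so the low reading of the earlier pyridin-4-yl compound cannot be attributed to that ring alone. The compounds shown leave open how a furan-2-yl ring or a phenyl ring carrying an amine would read at this position. No measurement shown explains why either step occurs.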